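Benzyl ether variation on the aryloxy arm

The source may hold more compounds than are shown below. What is called first, only, known or untested is meant among the compounds shown, and "the series" means these compounds.

Compound 1 `COc1cccc(OC)c1OCCNCCOc1ccccc1OCc1ccccc1C` is the reference point of this small set. In an assay on CHO cells for displacement of a labelled ligand from Alpha-1B adrenergic receptor (Homo sapiens) (a higher number here means a weaker inhibitor, a lower number a stronger inhibitor), compound 1 gives 0.794 nM, the second highest of the three numbers measured. Compound 2 `COc1cccc(OC)c1OCCNCCOc1ccccc1OCc1ccc(C)cc1` gives 0.251 nM in this assay, and compound 3 `COc1ccccc1COc1ccccc1OCCNCCOc1c(OC)cccc1OC` gives 6.31 nM. The step of a 3.2-fold lower number from compound 1 to compound 2 (0.50 log units; beyond the scatter) shows that 4-methylphenyl in place of 2-methylphenyl lowers the number, whereas a 7.9-fold higher number from compound 1 to compound 3 (0.90 log units; beyond the scatter) shows that methoxy in place of methyl on the aromatic carbon raises it. The step of a 25-fold higher number from compound 2 to compound 3 (1.40 log units; beyond the scatter) combines both differences and is the largest in the set.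

Compound 4 `COc1cccc(COc2ccccc2OCCNCCOc2c(OC)cccc2OC)c1` has not yet been measured. Relative to compound 1 the change is 3-methoxyphenyl in place of 2-methylphenyl on a saturated chain carbon bound to an oxygen on an aromatic ring. Both measured steps out of compound 1 bear on it: the methyl-to-methoxy exchange in compound 3 cost potency, while relocating the methyl in compound 2 gained some. The new group carries the methoxy at a third position, so neither step applies directly; a net rise in the number, smaller than that to compound 3, is the expectation. For compound 4 the estimated value in this assay is 2 nM, with a range from 0.6 nM to 6.3 nM. This estimate corresponds to an expected step of a 2.5-fold higher number from compound 1 to compound 4 (0.40 log units; beyond the scatter), a modest rise beyond the scatter.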

Compound 4, inhibition constant: 2 nM
Beside the measured number, compound 4's estimate shows no gap at the digits printed, and the stated range covers the measured number.
By their numbers in this assay, from the lowest: compound 2; then compound 1; then compound 4; then compound 3.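

Within this assay, the 2-methoxyphenyl and 3-methoxyphenyl groups can now be compared directly on the saturated chain carbon bound to an oxygen on an aromatic ring, and a 3.2-fold lower number from compound 3 to compound 4 (0.50 log units; beyond the scatter) shows that the place of the methoxy on the benzyl ring matters, not only its presence. For the compounds shown here, the methoxy penalty seen with compound 3 is therefore reduced in compound 4 but not removed: a 2.5-fold higher number from compound 1 to compound 4 (0.40 log units; beyond the scatter) and an 8.0-fold higher number from compound 2 to compound 4 (0.90 log units; beyond the scatter) leave both methoxy compounds above both methyl compounds, with no compound of the four going against that split. Nothing in the data accounts for these differences.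

On these data alone, whether the methoxy or the ring place sets the number remains open, since the comparison would need 3-methylphenyl to set against compound 4 and 4-methoxyphenyl to set against compound 2. As far as these compounds go, it is equally open whether the low number of compound 2 holds for other groups on that ring, such as 4-chlorophenyl or 4-carboxyphenyl.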